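Swapping the pendant aryl ring in a thiazolidinone series

The source may hold more compounds than are shown below. What is called first, only, known or untested is meant among the compounds shown, and "the series" means these compounds.

Measured so far:
Compound 1 `O=C1N/C(=N/c2csc(-c3ccc(Cl)cc3)c2)S/C1=C\c1ccc(Br)cc1`: 2500 nM
Compound 2 `COc1ccc(/C=C2\S/C(=N\c3csc(-c4ccc(Cl)cc4)c3)NC2=O)cc1OC`: 7600 nM

Compound 2 stands as the highest of the two numbers in a functional assay on MCF7 cells (Homo sapiens) for cytotoxicity, read by MTT assay, with a stated time of 72 h; on this read-out higher numbers stand for weaker inhibition and lower numbers for stronger inhibition; its nearest neighbour is compound 1, and a 3.0-fold higher number from compound 1 to compound 2 (0.48 log units; beyond the scatter). Compound 3 `O=C1N/C(=N/c2csc(-c3ccc(Cl)cc3)c2)S/C1=C\c1ccc(F)cc1` differs from compound 2 by 4-fluorophenyl in place of 3,4-dimethoxyphenyl on a double-bonded chain carbon bound to a double-bonded ring carbon. For the measured compounds named here, the only step that bears on this, a 3.0-fold higher number from compound 1 to compound 2 (0.48 log units; beyond the scatter), runs the other way: removing the dimethoxyphenyl in favour of a halophenyl. A reversal of similar size is therefore expected, giving a 2.5-fold lower number from compound 2 to compound 3 (0.40 log units; beyond the scatter). For compound 3 the expected value is 3000 nM, with a range from 1000 nM to 9000 nM.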

Compound 3, half-maximal inhibitory concentration: > 50000 nM
Compound 3 gave a limit, no number; the forecaster's own chance of this, stated with the estimate: 5%; middle value at least 16-fold (1.22 log units) from the limit.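

Compound 3 gave a limit, not a number: the limit of > 50000 nM in this assay, at which 1 of the 3 values shown sits. At this position the choice of halogen matters, since fluoro in place of bromo on an aromatic carbon gives an at least 20-fold higher number from compound 1 to compound 3 (1.30 log units; beyond the scatter), so one halophenyl ring cannot stand in for another. Replacing 3,4-dimethoxyphenyl with 4-fluorophenyl gives an at least 6.5-fold higher number from compound 2 to compound 3 (0.81 log units; beyond the scatter), so the halogen-free compound 2 falls between the two halophenyl compounds, and halophenyl does not beat dimethoxyphenyl as a rule.

Going by these compounds, it remains open whether chloro on that aromatic carbon would behave like bromo or like fluoro. How an amine there would read is also unknown.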